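Swapping an Acyl Group for a Sulfonyl Group

The compounds below may be only part of what the source reports. "The series", "measured", "known", "first", "only" and "open" are said of these compounds alone.

Of the compounds shown here, three have been measured in an assay on mitochondria for inhibition of HSP60/HSP10 (Homo sapiens); on this read-out lower numbers stand for stronger inhibition and higher numbers for weaker inhibition. Compound 1 `O=S(=O)(Nc1ccc(-c2nc3cc(NS(=O)(=O)c4ccccc4)ccc3o2)cc1)c1ccccc1` gives 86000 nM. Compound 2 `O=S(=O)(Nc1ccc(-c2nc3cc(NS(=O)(=O)c4ccc(Cl)s4)ccc3o2)cc1)c1ccc(Cl)c(C(F)(F)F)c1` gives 6700 nM. Compound 3 `COc1ccc(S(=O)(=O)Nc2ccc3oc(-c4ccc(NC(=O)c5cccc(C)c5[N+](=O)[O-])cc4)nc3c2)cc1` gives 72000 nM, which puts it second highest of the three numbers: its nearest neighbour is compound 1, whose number sits within the scatter of it, while compound 2 lies well beyond the scatter with a clearly lower number.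

Compound 4 `COc1ccc(S(=O)(=O)Nc2ccc3oc(-c4ccc(NS(=O)(=O)c5cc(F)ccc5OC)cc4)nc3c2)cc1` has not yet been measured. It differs from compound 3 in one place: a group of 12 heavy atoms (7 carbon, 3 oxygen, 1 fluorine, 1 sulfur; one six-membered aromatic ring of carbon only) in place of a group of 12 heavy atoms (8 carbon, 1 nitrogen, 3 oxygen; one six-membered aromatic ring of carbon only), on a nitrogen on an aromatic ring. The shared core is untouched.

Among the compounds with values here, no measured pair tells how this exact change plays out, so the expectation rests on the spread seen so far. Compounds 1 and 3, with plain phenyl-bearing groups on the outer nitrogen, both sit at the high end, and only compound 2 reaches far lower. A step of moderate size toward a lower number is expected from compound 3 to compound 4, namely a 1.8-fold lower number from compound 3 to compound 4 (0.26 log units; within the scatter). Compound 4 is therefore estimated at 40000 nM, with a likely range from 10000 nM to 150000 nM.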

Compound 4, half-maximal inhibitory concentration: > 100000 nM
Compound 4 ended at the assay's limit; the forecaster's own chance of this, stated with the estimate: 10%; middle value at least 2.5-fold (0.39 log units) away from the limit.
By their numbers in this assay, from the lowest: compound 2; then compounds 3 and 1 (each within the scatter of the next). At a limit, above all of these: compound 4.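

In this assay compound 4 gives > 100000 nM, which is a limit of the assay and not a number. On the nitrogen on an aromatic ring, putting the sulfur- and fluorine-bearing group in place of (3-methyl-2-nitrophenyl)carbonyl gives an at least 1.3-fold higher number from compound 3 to compound 4 (0.14 log units; that floor lies within the scatter). The change thus brings no lower number at this position, yet the floor of the step does not by itself establish a real loss, and the size of any loss cannot be read: the limit of > 100000 nM in this assay, at which 1 of the 4 values shown sits.

On these data alone, what stays open is whether the outcome follows from the sulfonyl link or from the substituents on the outer ring, as the two groups differ in both. A free amine or a small acetyl group on the same nitrogen would show how much this position depends on carrying an outer aromatic ring at all.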